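The compounds below may be only part of what the source reports. "The series", "measured", "known", "first", "only" and "open" are said of these compounds alone.

Compound 1 `CNCCN(C(=O)Nc1ccc(F)c(Cl)c1)c1ccc(-c2cccc(C#N)c2)cc1` and compound 2 `N#Cc1cccc(-c2ccc(N(CCN3CCCC3)C(=O)Nc3ccc(C(F)(F)F)c(F)c3)cc2)c1` make up the measured part of this series. In an assay on isolated protein for inhibition of melanin-concentrating hormone receptor 1 (Homo sapiens) (a lower number here means a stronger inhibitor, a higher number a weaker inhibitor), compound 1 gives 6 nM, and compound 2 gives 5.6 nM, two numbers that sit within the scatter of each other. Compound 3 `N#Cc1cccc(-c2ccc(N(CCN3CC[C@@H](O)C3)C(=O)Nc3ccc(F)c(Cl)c3)cc2)c1` is not yet measured; it differs from compound 1 by 3-hydroxypyrrolidin-1-yl in place of methylamino on a saturated chain carbon, two bonds along the chain from an amide-type nitrogen. Compound 2 already carries a pyrrolidinyl in place of the methylamino without moving the number, so no step beyond the scatter is expected from compound 1 to compound 3 no change at the digits printed from compound 1 to compound 3 (within the scatter). Compound 3 is estimated to give 6 nM in this assay, within 2.5 nM to 15 nM.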

Compound 3, inhibition constant: 7.1 nM
Compound 3: middle estimate off by 1.2-fold (0.07 log units), on the low side; the measured number falls inside the stated range.
By their numbers in this assay, from the lowest: compounds 2, 1 and 3 (each within the scatter of the next).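

In this assay, the one-place change on the core of compound 1 gives a 1.2-fold higher number from compound 1 to compound 3 (0.07 log units; within the scatter). At this position on the chain, 6 heavy atoms with a five-membered ring and a defined stereocentre are therefore accepted in place of the 2 heavy atoms of methylamino, with the number remaining within the scatter. No accompanying measurement offers an explanation for this result.

Still open, going by these compounds, is how a morpholine, a piperidine or a carboxylic acid would read at this place. On these data alone, the opposite configuration of the 3-hydroxypyrrolidin-1-yl stereocentre is also open.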